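The compounds below may be only part of what the source reports. "The series", "measured", "known", "first", "only" and "open" are said of these compounds alone.

Working notes on the series. Among the measured compounds shown here, in a functional assay on DU-145 cells (Homo sapiens) for cytotoxicity, read by MTT assay, with a stated time of 2 days (on this read-out higher numbers stand for weaker inhibition and lower numbers for stronger inhibition), compound 1 `CCCCCNc1nc(NCc2ccco2)c2cc(F)ccc2n1` gives 7240 nM and stands at the low end of the three numbers so far. Compound 3 `CCCCCNc1nc(NCc2ccco2)c2ccccc2n1` gives 11500 nM in this assay; the step of a 1.6-fold higher number from compound 1 to compound 3 (0.20 log units; within the scatter) is within the scatter, so the two are not separable. Compound 2 `CN(C)CCCNc1nc(NCc2ccco2)c2ccccc2n1` gives 51000 nM in this assay, and the step of a 4.4-fold lower number from compound 2 to compound 3 (0.65 log units; beyond the scatter) is the only one beyond the scatter in the set.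

Compound 4 `CCCCNc1nc(NCc2ccco2)c2cc(F)ccc2n1` differs from compound 1 by hydrogen in place of methyl on a saturated chain carbon, four bonds along the chain from a nitrogen on an aromatic ring. For the measured compounds named here, no measured pair shortens this chain by one carbon; the one change at the chain end, from compound 2 to compound 3, swaps a dimethylamino for an ethyl and does not bear directly on a hydrogen-for-methyl cut. Going by the values given here, with no measured step of the same kind, the expectation is no change beyond the scatter in this assay. For compound 4 the estimate in this assay is 8500 nM, with a range of 4000 nM to 18000 nM. The step expected from compound 1 to compound 4 is therefore a 1.2-fold higher number from compound 1 to compound 4 (0.07 log units; within the scatter).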

Compound 4, half-maximal inhibitory concentration: 5910 nM
Compound 4: the middle estimate sits 1.4-fold (0.16 log units) above what was measured, within the range that was stated.
By their numbers in this assay, from the lowest: compounds 4, 1 and 3 (each within the scatter of the next); then compound 2.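

The hydrogen-for-methyl change on a saturated chain carbon, four bonds along the chain from a nitrogen on an aromatic ring, can now be read directly in this assay, and it gives a 1.2-fold lower number from compound 1 to compound 4 (0.09 log units; within the scatter). Among the compounds shown here, with the fluoro-bearing core held fixed, this methyl can therefore be lost without a change that this read-out separates, whereas the only earlier change on the chain, a 4.4-fold lower number from compound 2 to compound 3 (0.65 log units; beyond the scatter), involved a dimethylamino group on a different carbon and went beyond the scatter. No measurement shown accounts for either result.

Going by these compounds, whether the chain can be cut further, to propyl or ethyl, or extended to a longer chain such as hexyl, remains open. Also open, on these data alone, is whether the same cut reads alike on the core without fluoro, or with a hydroxyl on this chain.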